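Aryl swap on the fused core: compound 3 to compound 4

A few compounds are considered here, and "the series" means these few. Any claim that something is new, unique, unknown or untested is made for them only; others in the source may bear on it.

Measured: compound 1 `Fc1ccc(-c2cn3nc(Cc4ccc(Cl)cc4)sc3n2)cc1`; compound 2 `Cc1ccc(-c2cn3nc(Cc4ccc(Cl)cc4)sc3n2)cc1`; compound 3 `Clc1ccc(Cc2nn3cc(-c4ccc(Cl)cc4Cl)nc3s2)cc1`.

In an ADME assay on CCRF-CEM cells (Homo sapiens) for cytotoxicity, with a stated time of 72 h (a lower number here means a stronger inhibitor, a higher number a weaker inhibitor), compound 1 returns only a limit, > 250000 nM. In this assay compound 2 likewise returns a limit, > 250000 nM. Compound 3 also sits at a limit in this assay, > 250000 nM. All three values rest at the limit of > 250000 nM in this assay, at which 3 of the 3 values shown sit, so the steps a step that the two limits leave unreadable from compound 1 to compound 2, a step that the two limits leave unreadable from compound 1 to compound 3 and a step that the two limits leave unreadable from compound 2 to compound 3 carry no readable size. Compound 4 `Clc1ccc(Cc2nn3cc(-c4ccccc4)nc3s2)cc1` differs from compound 3 by phenyl in place of 2,4-dichlorophenyl on an aromatic carbon. Going by the values given here, no measured step bears readably on this change, and every aryl variant so far stands at the limit. Compound 4 is therefore expected to remain near 250000 nM, with an expected range of 100000 nM to 600000 nM. The step of a number no higher from compound 3 to compound 4 (the limit leaves the size open) is expected to be none beyond the scatter.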

Compound 4, half-maximal inhibitory concentration: > 250000 nM
Compound 4: only a limit was reported; the forecaster's own chance of this, stated with the estimate: 85%; the middle value lies on the limit itself.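

Compound 4 returns only a limit, so its steps from compound 1, compound 2 and compound 3 cannot be read: the limit of > 250000 nM in this assay, at which 4 of the 4 values shown sit.
The compounds shown leave open how far any aryl variant on the shared core lies from that limit in this assay.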